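Aryl variation on the shared core: the step to compound 4

The source may hold more compounds than are shown below. What is called first, only, known or untested is meant among the compounds shown, and "the series" means these compounds.

Compound 1 `Fc1ccc(-c2cn3ccnc3c(-c3ccc4ncn(C5CCCCC5)c4c3)n2)cc1` gives 12.8% in a functional assay on A549 cells (Homo sapiens) for inhibition, read by sulforhodamine B assay, with a stated time of 48 h, tested at 10 uM; a higher number here means more inhibition at the concentration tested (going by the name of the read-out), a lower number less inhibition. Within the data shown here, it stands highest of the three numbers measured so far, but only by margins within the scatter: compound 2 `Clc1ccc(-c2cn3ccnc3c(-c3ccc4ncn(C5CCCCC5)c4c3)n2)cc1`, with 11.6%, lies nearest, and compound 3 `c1csc(-c2cn3ccnc3c(-c3ccc4ncn(C5CCCCC5)c4c3)n2)c1`, with 5.33%, furthest. The three steps connecting them are all small. The step of a number 1.2 percentage points lower from compound 1 to compound 2 (within the scatter) came with chloro in place of fluoro on an aromatic carbon; the step of a number 7.5 percentage points lower from compound 1 to compound 3 (within the scatter) came with thiophen-2-yl in place of 4-fluorophenyl on an aromatic carbon; the step of a number 6.3 percentage points lower from compound 2 to compound 3 (within the scatter) came with thiophen-2-yl in place of 4-chlorophenyl on an aromatic carbon. None of them moved the read-out beyond the scatter, so the aryl group at this position has so far had no resolved effect.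

Compound 4 `FC(F)(F)c1cccc(-c2cn3ccnc3c(-c3ccc4ncn(C5CCCCC5)c4c3)n2)c1` differs from compound 1 in one place: 3-(trifluoromethyl)phenyl in place of 4-fluorophenyl on an aromatic carbon. The two steps that bear on it are those from compound 1, both within the scatter, and neither gives ground to expect a larger move here. The step expected in this assay is therefore a number 1.8 percentage points lower from compound 1 to compound 4 (within the scatter), that is, none beyond the scatter. Compound 4 is expected to give about 11%, estimated between 2% and 22%.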

Compound 4, a percentage reported as inhibition, at one concentration (the size of the read-out at that concentration, not a potency): 5.15%
The estimate for compound 4 lay 5.9 percentage points above the measured number, and the stated range covers the measured number.
By their numbers in this assay, from the lowest: compounds 4, 3, 2 and 1 (each within the scatter of the next).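

The only 3-substituted phenyl in the set, 3-(trifluoromethyl)phenyl, gives no resolved effect in this assay against any of the other aryl groups: the steps read a number 7.7 percentage points lower from compound 1 to compound 4 (within the scatter), a number 6.5 percentage points lower from compound 2 to compound 4 (within the scatter) and a number 0.2 percentage points lower from compound 3 to compound 4 (within the scatter). The position on the shared core therefore now carries four different aryl groups with every step within the scatter, and this holds even with the substituent's place on the phenyl ring and its identity changed together, with the entering group counting more heavy atoms than 4-fluorophenyl. No measured evidence on this position is available to explain the result.

From the compounds shown here alone, whether an aryl group can be told apart from a group of another kind remains open: an amine or a carboxylic acid on a non-aromatic chain at this position might or might not give a step beyond the scatter. Also open, going by these compounds, is how trifluoromethyl would read in the 4-position of the phenyl ring, which would separate the effect of its place from that of its identity.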